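The compounds below may be only part of what the source reports. "The series", "measured", "known", "first", "only" and "open" are said of these compounds alone.

Measured in a functional assay on DLD-1 cells (Homo sapiens) for cytotoxicity, with a stated time of 48 h; on this read-out higher numbers stand for weaker inhibition and lower numbers for stronger inhibition:
- compound 1 `CC(=O)Oc1ccc2oc(/C=C/[S+](C)[O-])cc(=O)c2c1`: > 10000 nM
- compound 2 `COc1ccc2c(=O)cc(/C=C/[S+](C)[O-])oc2c1`: 7800 nM

In this assay compound 1 stands at > 10000 nM, which is a limit of the assay and not a number. Its place in this small set is thus (the limit of > 10000 nM in this assay, at which 1 of the 2 values shown sits). Going by the values given here, compound 2 gives 7800 nM, the only actual number so far, and no measured step joins the two compounds.

The next compound is compound 3 `CCCCC(=O)Oc1ccc2oc(/C=C/[S+](C)[O-])cc(=O)c2c1`, which keeps the core of compound 1 and alters only the ester. The change is propyl in place of hydrogen on a saturated chain carbon bound to a carbonyl carbon, so that acetoxy becomes (butylcarbonyl)oxy.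

Among the compounds with values here, with no measured step as a guide, only a small shift in this assay is expected, perhaps towards stronger inhibition, and perhaps none beyond the scatter. Within the data shown here, the one number available, from compound 2 at 7800 nM, suggests that weak inhibition is the likely outcome. The expected step is an at least 1.1-fold lower number from compound 1 to compound 3 (0.04 log units; that floor lies within the scatter). For compound 3 the estimated value is 9000 nM, with an expected range from 3000 nM to 20000 nM.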

Compound 3, half-maximal inhibitory concentration: 6700 nM
Estimate against measurement, compound 3: 1.3-fold (0.13 log units) above, within the range that was stated.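

In this assay, going by these compounds alone, the exchange of hydrogen for propyl on the saturated chain carbon bound to a carbonyl carbon, which turns acetoxy into (butylcarbonyl)oxy, gives an at least 1.4-fold lower number from compound 1 to compound 3 (0.17 log units; that floor lies within the scatter) and is the only measured step at this position. With compound 3 at 6700 nM the ester series now holds an actual number. This position thus tolerates the added propyl without the read-out reaching the limit of the assay, although the floor of the step does not by itself establish a change beyond the usual scatter. The full size of the step cannot be read because compound 1 stands at a limit and not at a number: the limit of > 10000 nM in this assay, at which 1 of the 3 values shown sits.

Going by these compounds, one step gives no trend, and it remains open whether a chain longer than butyl, a branched chain or a ring on the carbonyl carbon would carry the number further in the same direction. On these data alone, it also remains open how an amide or a free hydroxyl in place of the ester would read in this assay on the same core.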